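This account rests on a few compounds, and the source may have more. Where it says the series, first, only, none or still open, it means among the compounds named here.

Within the data shown here, compound 1 `Cc1n[nH]cc1-c1cccc2c1CCC2c1ncc[nH]1` gives 902 nM in a functional assay on CHO cells for agonist activity at Alpha-1B adrenergic receptor (Homo sapiens), read by FLIPR and calcium flux (a lower number here means that less compound is needed, a higher number that more compound is needed for the effect), and it holds the only number among the three measured compounds. Compound 2 `Cn1ccc(-c2cccc3c2CCC3c2ncc[nH]2)n1` reaches only the limit of > 10000 nM in this assay. Compound 3 `c1cncc(-c2cccc3c2CCC3c2ncc[nH]2)c1` likewise reaches only the limit of > 10000 nM. Both of those results sit at the limit of > 10000 nM in this assay, at which 2 of the 3 values shown sit. The step of an at least 11-fold higher number from compound 1 to compound 2 (1.04 log units; beyond the scatter) and the step of an at least 11-fold higher number from compound 1 to compound 3 (1.04 log units; beyond the scatter) are both large, so each replacement of the 3-methyl-1H-pyrazol-4-yl tried so far pushed the number past the limit. Compound 4 `Cc1oncc1-c1cccc2c1CCC2c1ncc[nH]1` carries a change at the same place: 5-methyl-1,2-oxazol-4-yl in place of 3-methyl-1H-pyrazol-4-yl on an aromatic carbon. With both measured steps pointing the same way, a large rise in the number is expected for compound 4, with an estimate of 5000 nM, between 1500 nM and 20000 nM. That would be an expected step of a 5.5-fold higher number from compound 1 to compound 4 (0.74 log units; beyond the scatter).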

Compound 4, half-maximal effective concentration: > 10000 nM
Compound 4 ended at the assay's limit; the forecaster's own chance of this, stated with the estimate: 45%; middle value at least 2.0-fold (0.30 log units) from the limit.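

Even a replacement that keeps the six heavy atoms and a five-membered aromatic ring with 2 hetero atoms does not hold up: 5-methyl-1,2-oxazol-4-yl gives an at least 11-fold higher number from compound 1 to compound 4 (1.04 log units; beyond the scatter). The group that enters has 0 hydrogen-bond donors where the group that leaves has 1, although this single change cannot show that this difference is what counts. The steps among compounds 2, 3 and 4 cannot be read, since all three share one limit: the limit of > 10000 nM in this assay, at which 3 of the 4 values shown sit.

Going by these compounds, it remains open whether a 1H-pyrazol-4-yl without the methyl, or with an ethyl instead, would keep a readable number. Whether the hydrogen-bond donor matters on its own also stays unresolved.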